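The source may report more compounds than this note shows. Statements on the series, on what has been measured and on what is new or still open speak of the compounds shown alone.

Measured so far in an assay for inhibition of serine/threonine-protein kinase Sgk1 (Homo sapiens), with stated times of 30 min and 60 min, in the presence of a further agent that is not named here; a lower number here means a stronger inhibitor, a higher number a weaker inhibitor:
- compound 1 `O=C(NC1CCN(C2CC2)C1)c1cc(-c2ccc(NS(=O)(=O)c3cccc(Cl)c3Cl)cc2)nc2[nH]ncc12`: 6 nM
- compound 2 `CC(C)NC(=O)c1cc(-c2ccc(NS(=O)(=O)c3cccc(Cl)c3Cl)cc2)nc2[nH]ncc12`: 68 nM
- compound 3 `Cc1n[nH]c2nc(-c3ccc(NS(=O)(=O)c4cc(Cl)ccc4F)cc3)nc(OCCC(=O)N(C)C)c12`: 15 nM

Compound 3 stands second of the three numbers in this assay: compound 1 gives a lower number and compound 2 a higher one, both gaps beyond the scatter. Compound 4 `Cc1n[nH]c2nc(-c3ccc(NS(=O)(=O)c4cc(Cl)ccc4F)cc3)nc(OCC3CNCCO3)c12` differs from compound 3 by morpholin-2-yl in place of (dimethylcarbamoyl)methyl on a saturated chain carbon bound to an oxygen on an aromatic ring. Among the compounds with values here, the only measured step, an 11-fold higher number from compound 1 to compound 2 (1.05 log units; beyond the scatter), concerns an amide-type nitrogen on a different core and a different part of the molecule, so it bears on the present change only loosely; it does show that a ring bearing a nitrogen, in place of an open chain, went with the lower number. Within the data shown here, no measured pair touches the ether chain itself. The expected step of a 1.5-fold lower number from compound 3 to compound 4 (0.18 log units; within the scatter) is therefore small, slightly toward a lower number and not clearly beyond the scatter. Compound 4 is estimated at 10 nM, with a range of 3 nM to 40 nM.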

Compound 4, half-maximal inhibitory concentration: 2 nM
Estimate against measurement, compound 4: 5.0-fold (0.70 log units) above; the measured number lies below the stated range.
By their numbers in this assay, from the lowest: compound 4; then compound 1; then compound 3; then compound 2.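

In this assay morpholin-2-yl in place of (dimethylcarbamoyl)methyl gives a 7.5-fold lower number from compound 3 to compound 4 (0.88 log units; beyond the scatter) and so shows that this position, on a saturated chain carbon bound to an oxygen on an aromatic ring, responds to a change that keeps the same atoms. The step goes with one six-membered non-aromatic ring and a hydrogen-bond donor replacing an open chain. Nothing measured here explains it.

Open, going by these compounds, is whether the step follows the ring or its nitrogen hydrogen. A tetrahydropyran-2-yl or 4-methylmorpholin-2-yl group at this place would separate the two.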